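The source may report more compounds than this note shows. Statements on the series, on what has been measured and on what is new or still open speak of the compounds shown alone.

Compound 1 `CC(=O)SCC(=O)c1ccc(NS(=O)(=O)c2ccc(OCCCN3CCCCC3)cc2)nc1` gives 800 nM in a functional assay on U226 cells (Homo sapiens) for cytotoxicity; on this read-out higher numbers stand for an effect only at larger amounts of compound and lower numbers for an effect already at smaller amounts. Compound 2 `CC(=O)SCC(=O)c1ccc(NS(=O)(=O)c2ccc(OCCCc3ccccn3)cc2)nc1` replaces the chain of compound 1 with a 3-(pyridin-2-yl)propyl group, yet for compound 2 the entry in this assay reads "not determined" (no result reported), so it stands without a number of its own. Compound 3 `COc1cccc(S(=O)(=O)Nc2ccc(C(=O)CSC(C)=O)cn2)c1` is a second entry with no single number, its result in this assay being "not determined" (no result reported). Compound 4 `CC(=O)SCC(=O)c1ccc(NS(=O)(=O)c2ccc(OC3CCN(C)CC3)cc2)nc1` has not yet been tested. It differs from compound 2 by 1-methylpiperidin-4-yl in place of 3-(pyridin-2-yl)propyl on an oxygen on an aromatic ring, so the 1-methylpiperidin-4-yl group again brings a ring with a nitrogen atom onto the oxygen on the aromatic ring, as in compound 1. With no measured step available for this change, the only anchor is compound 1, whose value 800 nM is the single measured result among these compounds. Compound 4 is therefore expected to land near 1000 nM, within a range of 300 nM to 4000 nM.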

Compound 4, half-maximal effective concentration: 300 nM
Beside the measured number, compound 4's estimate is 3.3-fold (0.52 log units) above it, and the stated range covers the measured number.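

Within the data shown here, the earlier compounds gave only one number at this oxygen on the aromatic ring, so nothing could be said about how that number responds to a change there. In this assay, replacing 3-(piperidin-1-yl)propyl with 1-methylpiperidin-4-yl now gives a 2.7-fold lower number from compound 1 to compound 4 (0.43 log units; beyond the scatter), a modest change but beyond the scatter, which shows that this position tolerates a change in how the nitrogen-bearing ring is attached: a six-membered ring on the oxygen itself serves at least as well as one at the end of a propyl chain. The compounds shown offer no explanation for this difference, and the comparison with 3-(pyridin-2-yl)propyl cannot be read.

On these data alone, it remains open whether the ring nitrogen matters at all, since a cyclohexyl group would test this. A morpholine ring or a shorter 2-(piperidin-1-yl)ethyl chain could show how far the trend extends.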